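Removing the Carbonyl Between Core and Side Chain

The source may hold more compounds than are shown below. What is called first, only, known or untested is meant among the compounds shown, and "the series" means these compounds.

In a functional assay on WI-38 VA13 cells (Homo sapiens) for cytotoxicity (on this read-out lower numbers stand for an effect already at smaller amounts and higher numbers for an effect only at larger amounts of compound), compound 2 `CCNC(=O)Nc1nc2ccc(NC(=O)c3c(Cl)cccc3Cl)cc2s1` gives 0.032 ug/mL, the lowest of the two numbers measured, while compound 1 `O=C(Nc1nc2ccc(NC(=O)c3c(Cl)cccc3Cl)cc2s1)Oc1ccccc1` gives 1.1 ug/mL. For the measured compounds named here, the only measured step, a 34-fold lower number from compound 1 to compound 2 (1.54 log units; beyond the scatter), altered the group on the carbonyl carbon. Compound 3 `COc1cccc(Nc2nc3ccc(NC(=O)c4c(Cl)cccc4Cl)cc3s2)c1` differs from compound 2 by 3-methoxyphenyl in place of ethylcarbamoyl on a nitrogen on an aromatic ring, which takes away the carbonyl entirely, so that step bears on it only loosely. Because compound 1 with its phenoxy group gives 1.1 ug/mL, a move toward higher numbers is expected, a 16-fold higher number from compound 2 to compound 3 (1.19 log units; beyond the scatter). Compound 3 is estimated at 0.5 ug/mL, within a range from 0.05 ug/mL to 5 ug/mL.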

Compound 3, half-maximal effective concentration: > 7.2 ug/mL
Compound 3: only a limit was reported; the forecaster's own chance of this, stated with the estimate: 5%; at least 14-fold (1.15 log units) between middle value and limit.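

On the nitrogen on an aromatic ring, 3-methoxyphenyl in place of ethylcarbamoyl gives an at least 220-fold higher number from compound 2 to compound 3 (2.35 log units; beyond the scatter), and in place of phenoxycarbonyl it gives an at least 6.5-fold higher number from compound 1 to compound 3 (0.81 log units; beyond the scatter). Both groups that carry a carbonyl on this nitrogen therefore sit at lower numbers than the aryl group attached directly, a contrast the earlier pair, which both kept the carbonyl, could not show. The reading for compound 3 in this assay is a limit and not a number: the limit of > 7.2 ug/mL in this assay, at which 1 of the 3 values shown sits.

The change removes the carbonyl and brings in the ring together, so the compounds shown do not separate the two. An ethyl group set directly on this nitrogen would bear on that question.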